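The source may hold more compounds than are shown below. What is called first, only, known or untested is meant among the compounds shown, and "the series" means these compounds.

Measured compounds:
Compound 1 `Cc1ccc2nc(NCCCCOc3cc(O)c4c(=O)cc(-c5ccccc5)oc4c3)sc2c1` gives 8.79 ug/mL in a physicochemical assay, read by spectrophotometry, with a stated time of 10 min; a higher number here means a weaker inhibitor, a lower number a stronger inhibitor.
Compound 2 `O=c1cc(-c2ccccc2)oc2cc(OCCCCNc3nc4ccc([N+](=O)[O-])cc4s3)cc(O)c12` gives 8.14 ug/mL.
Compound 3 `O=c1cc(-c2ccccc2)oc2cc(OCCCCNc3nc4ccc(Br)cc4s3)cc(O)c12` gives 6.57 ug/mL.

Compound 3 has the lowest of the three numbers, but its gaps to the other two are small: a 1.2-fold lower number from compound 2 to compound 3 (0.09 log units; within the scatter) and a 1.3-fold lower number from compound 1 to compound 3 (0.13 log units; within the scatter) both fall within the scatter, so the three compounds cannot be ranked on these data.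

Compound 4 `O=c1cc(-c2ccccc2)oc2cc(OCCCCNc3nc4c(F)cc(F)cc4s3)cc(O)c12` differs from compound 3 in one place: 4,6-difluoro-1,3-benzothiazol-2-yl in place of 6-bromo-1,3-benzothiazol-2-yl on an amine nitrogen. All three measured steps bear on this change, since each swaps the substituent on the same aromatic ring of the shared core: a 1.1-fold lower number from compound 1 to compound 2 (0.03 log units; within the scatter), a 1.3-fold lower number from compound 1 to compound 3 (0.13 log units; within the scatter) and a 1.2-fold lower number from compound 2 to compound 3 (0.09 log units; within the scatter). None of them moved the number beyond the scatter, so a halogen swap on this ring is expected to leave the result where it is. Compound 4 is therefore estimated at 7 ug/mL, with a range of 4.5 ug/mL to 11 ug/mL, which means an expected step of a 1.1-fold higher number from compound 3 to compound 4 (0.03 log units; within the scatter).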

Compound 4, half-maximal inhibitory concentration: 5.76 ug/mL
Beside the measured number, compound 4's estimate is 1.2-fold (0.08 log units) above it; the range from low to high includes it.
By their numbers in this assay, from the lowest: compounds 4, 3, 2 and 1 (each within the scatter of the next).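

Among the compounds shown here, the 4,6-difluoro-1,3-benzothiazol-2-yl group adds something the earlier compounds lacked, a ring with two substituents instead of one, and in this assay the steps to it read a 1.1-fold lower number from compound 3 to compound 4 (0.06 log units; within the scatter) and a 1.4-fold lower number from compound 2 to compound 4 (0.15 log units; within the scatter) and a 1.5-fold lower number from compound 1 to compound 4 (0.18 log units; within the scatter) across the three earlier groups. Even the widest of these steps stays within the scatter, so adding a second substituent, and fluorine in place of bromo, nitro or methyl, gives no separation among the four compounds on the amine nitrogen. Nothing available here accounts for this flat result.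

From the compounds shown here alone, it remains open whether any change at this place can move the number beyond the scatter, for example an amine or a carboxylic acid on the ring. A longer chain in place of the present one is also untested among these compounds.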